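The compounds below may be only part of what the source reports. "The series", "measured", "known", "first", "only" and "open" are said of these compounds alone.

Working notes on the series in a functional assay on SGC-7901 cells (Homo sapiens) for antiproliferative activity, read by MTT assay, with a stated time of 48 h; on this read-out lower numbers stand for stronger inhibition and higher numbers for weaker inhibition. Compound 1 `Cc1ccc(-c2nnc(SCc3ccc(Cl)nc3)o2)cc1` gives 3.62 ug/mL and compound 2 `Fc1ccccc1-c1nnc(SCc2ccc(Cl)nc2)o1` gives 9.12 ug/mL, so compound 2 holds the higher of the two numbers. Compound 3 `Clc1ccc(CSc2nnc(-c3ccccc3Cl)o2)cn1` differs from compound 2 by chloro in place of fluoro on an aromatic carbon, ortho to a large group, turning 2-fluorophenyl into 2-chlorophenyl. Within the data shown here, only one measured step bears on this, and only indirectly: a 2.5-fold higher number from compound 1 to compound 2 (0.40 log units; beyond the scatter), with 2-fluorophenyl in place of 4-methylphenyl. Among the measured compounds shown here, that modest step swaps a different pair of groups, and no measured step tests chloro against fluoro. As far as these compounds go, no step beyond the scatter is therefore expected, and the direction stays open, with compound 2 at 9.12 ug/mL as the anchor. The expected change is a 1.2-fold lower number from compound 2 to compound 3 (0.08 log units; within the scatter). For compound 3 the estimated value in this assay is 7.5 ug/mL, with an expected range of 3 ug/mL to 18 ug/mL.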

Compound 3, half-maximal inhibitory concentration: 13.5 ug/mL
Estimate against measurement, compound 3: 1.8-fold (0.26 log units) below, within the range that was stated.
By their numbers in this assay, from the lowest: compound 1; then compounds 2 and 3 (each within the scatter of the next).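

In this assay, among these compounds, chloro in place of fluoro on an aromatic carbon, ortho to a large group, gives a 1.5-fold higher number from compound 2 to compound 3 (0.17 log units; within the scatter) and so offers the first direct comparison of these two groups, which this read-out does not separate. Against 4-methylphenyl, 2-chlorophenyl gives a 3.7-fold higher number from compound 1 to compound 3 (0.57 log units; beyond the scatter) and so repeats the gap first seen with 2-fluorophenyl, with compound 1 now apart from two compounds rather than one. No measured evidence accounts for either step.

Still open, as far as these compounds go, is whether the gap to compound 1 follows the methyl group or its place, since 4-methylphenyl and 2-chlorophenyl differ in both. Also open, from the compounds shown here alone, is how an amine or a methoxy group would read in place of chloro on the same aromatic carbon.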